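This account rests on a few compounds, and the source may have more. Where it says the series, first, only, none or still open, it means among the compounds named here.

Two compounds have been measured in an assay on isolated protein for inhibition of Amine oxidase [flavin-containing] B (Homo sapiens), read by fluorescence; on this read-out lower numbers stand for stronger inhibition and higher numbers for weaker inhibition:

Compound 1 `O=C(/C=C/c1ccsc1)c1cc(O)c(O)c([N+](=O)[O-])c1` gives 42100 nM in this assay.
Compound 2 `CC(=O)N1N=C(c2cc(O)c(O)c([N+](=O)[O-])c2)CC1c1ccc(C#N)cc1` gives 83200 nM in this assay.

For the measured compounds named here, compound 2 holds the highest of the two numbers measured so far, but its nearest neighbour is compound 1, and the gap between the two is within the usual scatter of this assay, so the two values should be read as alike rather than ordered. Both compounds share the same catechol-nitro aryl unit and both are weak inhibitors on this read-out.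

Compound 3 `CC(=O)N1N=C(c2cc(O)c(O)c([N+](=O)[O-])c2)CC1c1cccc(C#N)c1` differs from compound 2 only in one place: 3-cyanophenyl in place of 4-cyanophenyl on a saturated ring carbon. The acetyl-bearing five-membered ring and the shared core are untouched. Going by the values given here, no pair of measured compounds shows what moving a nitrile around the pendant phenyl ring does here, so the size of the step is uncertain. Given that the two measured compounds, compound 1 and compound 2, sit so close together despite a far larger structural difference, a shift of the nitrile is expected to move the number by a 1.2-fold lower number from compound 2 to compound 3 (0.08 log units; within the scatter), a change not clearly beyond the scatter. Compound 3 is therefore estimated to give 70000 nM in this assay, with a range of 25000 nM to 200000 nM.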

Compound 3, half-maximal inhibitory concentration: 55400 nM
Compound 3: the middle estimate sits 1.3-fold (0.10 log units) above what was measured, within the range that was stated.
By their numbers in this assay, from the lowest: compounds 1, 3 and 2 (each within the scatter of the next).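

For the compounds shown here, the swap of 4-cyanophenyl for 3-cyanophenyl on the saturated ring carbon gives the first direct reading at this position: in this assay it amounts to a 1.5-fold lower number from compound 2 to compound 3 (0.18 log units; within the scatter). The two nitrile placements therefore cannot be told apart on this read-out, and where the nitrile stands on the pendant phenyl ring is not shown to matter for this pair, which remains in the same weak range. Nothing further is available that would explain why the two read alike.

As far as these compounds go, whether this saturated ring carbon responds to any change at all stays open, since compound 2 and compound 3 carry only cyanophenyl there and cannot say how a plain phenyl, or a phenyl bearing an amine or a carboxylic acid, would read. They also leave open how much the number depends on the acetyl group, which both share, and whether a longer chain such as butanoyl on that ring atom would read any differently.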